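Holding stability while swapping the amide ring

A few compounds are considered here, and "the series" means these few. Any claim that something is new, unique, unknown or untested is made for them only; others in the source may bear on it.

Compound 1 `Fc1ccc(Nc2cc3[nH]c(Nc4cc(N5CCNCC5)ccn4)nc3cn2)cc1C(F)(F)F`: 98%
Compound 2 `C[C@@H]1CN(C(=O)c2ccnc(Nc3nc4cnc(Nc5ccc(F)c(C(F)(F)F)c5)cc4[nH]3)c2)C[C@H](C)N1`: 89%

In an ADME assay on microsomes from liver (Homo sapiens) for metabolic stability, read by LC-MS, using NADPH, with a stated time of 60 min, tested at 0.1 uM (on this read-out higher numbers stand for a more stable compound and lower numbers for a less stable compound), compound 2 gives 89%, which lies within the scatter of compound 1 at 98%. Compound 3 `C[C@@H]1CN(C(=O)c2ccnc(Nc3nc4cnc(Nc5ccc(F)c(C(F)(F)F)c5)cc4[nH]3)c2)C[C@H](C)O1` has 2,6-dimethylmorpholin-4-yl in place of 3,5-dimethylpiperazin-1-yl on a carbonyl carbon. Going by the values given here, no measured pair shows this exchange directly. Among the compounds with values here, the nearest evidence is the only measured step, a number 9 percentage points lower from compound 1 to compound 2 (within the scatter), which put (3,5-dimethylpiperazin-1-yl)carbonyl in place of piperazin-1-yl on an aromatic carbon. That step gives no sign of a large shift in this assay, though it rests on a single pair of compounds. The expected result is a number 3 percentage points lower from compound 2 to compound 3 (within the scatter), so no step beyond the scatter is anticipated. For compound 3 the estimated value is 86%, with an expected range from 72% to 97%.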

Compound 3, percent of the compound remaining: 63%
Estimate against measurement, compound 3: 23 percentage points above; the whole stated range lies above it.
By their numbers in this assay, from the lowest: compound 3; then compounds 2 and 1 (each within the scatter of the next).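

At the carbonyl carbon, 2,6-dimethylmorpholin-4-yl in place of 3,5-dimethylpiperazin-1-yl gives, in this assay, a number 26 percentage points lower from compound 2 to compound 3 (beyond the scatter), so this position responds to a change that leaves the heavy-atom count the same and swaps one ring nitrogen for oxygen. Going by these compounds alone, the wider change reads a number 35 percentage points lower from compound 1 to compound 3 (beyond the scatter), whereas the only earlier step stayed within the scatter, so the ring on this carbonyl can matter for this read-out even though the 3,5-dimethylpiperazin-1-yl amide did not show it. Nothing measured here bears on why the number falls.

Going by these compounds, whether the fall goes with the ring oxygen itself or with the loss of the ring's hydrogen-bond donor remains open. A 3,4,5-trimethylpiperazin-1-yl on the same carbonyl carbon would separate the two, and a plain morpholin-4-yl would show what the two methyl groups contribute.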